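Side-ring substituent swap in the dihydroxychromone amines

The source may report more compounds than this note shows. Statements on the series, on what has been measured and on what is new or still open speak of the compounds shown alone.

Compound 1 `Cc1ccccc1CNCc1cc(=O)c2c(O)c(O)ccc2o1` gives 52200 nM in an ADME assay on Huh-7 cells (Homo sapiens) for cytotoxicity; on this read-out lower numbers stand for higher toxicity in this test and higher numbers for lower toxicity in this test. Compound 2 `O=c1cc(CNCc2cccc(Cl)c2)oc2ccc(O)c(O)c12` reaches only the limit > 100000 nM in this assay. Compound 3 `O=c1cc(CNCc2cccc(Br)c2)oc2ccc(O)c(O)c12` likewise sits at the limit > 100000 nM in this assay, so its standing is known only as a bound, shared with the limit of > 100000 nM in this assay, at which 2 of the 3 values shown sit. The steps of an at least 1.9-fold higher number from compound 1 to compound 2 (0.28 log units; that floor lies within the scatter) and an at least 1.9-fold higher number from compound 1 to compound 3 (0.28 log units; that floor lies within the scatter) are floors within the scatter; the step that the two limits leave unreadable from compound 2 to compound 3 cannot be read. Compound 4 `O=c1cc(CNCc2cccc(O)c2)oc2ccc(O)c(O)c12` differs from compound 3 by hydroxy in place of bromo on an aromatic carbon. For the measured compounds named here, no measured step isolates this change; the nearest, the halogen swap between compound 2 and compound 3, is unreadable, and the moves from compound 1 give only small floors. The expected step is therefore none beyond the scatter, a number no higher from compound 3 to compound 4 (the limit leaves the size open). Compound 4 is estimated near 100000 nM, within 40000 nM to 250000 nM.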

Compound 4, half-maximal cytotoxic concentration: > 100000 nM
Compound 4 ended at the assay's limit; the forecaster's own chance of this, stated with the estimate: 60%; the middle value sits exactly at the limit.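

With hydroxy on this aromatic carbon, compound 4 shows that a group carrying a hydrogen-bond donor and acceptor also leaves the number at a limit, as with chloro in compound 2 and bromo in compound 3: the limit of > 100000 nM in this assay, at which 3 of the 4 values shown sit.

The steps among these three compounds cannot be read, as both ends of each are limits. For the compounds shown here, the one readable step is an at least 1.9-fold higher number from compound 1 to compound 4 (0.28 log units; that floor lies within the scatter).

Going by these compounds, how a carboxylic acid or an amine on this carbon would read in this assay remains open. So does whether any group here gives a value inside the assay's range.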